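Lengthening a Straight Chain on One Shared Core

The source may report more compounds than this note shows. Statements on the series, on what has been measured and on what is new or still open speak of the compounds shown alone.

Three measured compounds share one core and differ only in the length of a straight chain attached to it. Compound 1 `CCCc1ccc(-c2c(C)[nH]c(=O)n2C)cc1` carries the shortest chain, and in a functional assay on brain (Rattus norvegicus, strain Wistar) for inhibition (on this read-out lower numbers stand for stronger inhibition and higher numbers for weaker inhibition), compound 1 gives 21500 nM. Compound 2 `CCCCCCCc1ccc(-c2c(C)[nH]c(=O)n2C)cc1` carries a longer chain, and in this assay compound 2 gives 8400 nM. The change from compound 1 to compound 2 is butyl in place of hydrogen on a saturated chain carbon, three bonds along the chain from an aromatic carbon, and it made a 2.6-fold lower number from compound 1 to compound 2 (0.41 log units; beyond the scatter). Compound 3 `CCCCCCCCCCCCCCc1ccc(-c2c(C)[nH]c(=O)n2C)cc1` carries a longer chain still; in this assay compound 3 gives 43800 nM, which is a 5.2-fold higher number from compound 2 to compound 3 (0.72 log units; beyond the scatter). The difference between compound 1 and compound 3 is not broken down here. Among the three, compound 3 gives the highest number.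

Compound 4 `CCCCCCCCCCCCCCCCCCc1ccc(-c2c(C)[nH]c(=O)n2C)cc1` has not yet been measured. It differs from compound 3 by butyl in place of hydrogen on a saturated chain carbon, ten or more bonds along the chain from an aromatic carbon. This is the same kind of change as from compound 1 to compound 2, but the place along the chain differs, as the two descriptions of the changes show. The earlier step lowered the number, yet further lengthening then raised it, as seen in a 5.2-fold higher number from compound 2 to compound 3 (0.72 log units; beyond the scatter). Compound 4 is therefore expected to give a higher number than compound 3, with an expected step of a 2.1-fold higher number from compound 3 to compound 4 (0.31 log units; beyond the scatter), because a 5.2-fold higher number from compound 2 to compound 3 (0.72 log units; beyond the scatter) points in that direction. The estimate for compound 4 in this assay is 90000 nM, expected to lie between 30000 nM and 300000 nM.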

Compound 4, half-maximal inhibitory concentration: > 100000 nM
Compound 4: no number, only a limit; the forecaster's own chance of this, stated with the estimate: 35%; at least 1.1-fold (0.04 log units) between middle value and limit.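

In this assay compound 4 gives > 100000 nM, which is a limit of the assay and not a number. Butyl in place of hydrogen gave an at least 2.2-fold higher number from compound 3 to compound 4 (0.35 log units; beyond the scatter), so the kind of change that strengthened inhibition when made on the shorter chain of compound 1 weakened it when made on the long chain of compound 3, and its effect did not carry over from one to the other: the same change on two cores in this assay, a 2.6-fold lower number (0.41 log units; beyond the scatter) from compound 1 to compound 2 and an at least 2.2-fold higher number (0.35 log units; beyond the scatter) from compound 3 to compound 4, at least 5.8-fold (0.76 log units) apart, beyond the scatter of two such steps This shows the direction of the new step but not its true size, and it gives no explanation for the reversal, since the result for compound 4 marks only the edge of what the assay reports: the limit of > 100000 nM in this assay, at which 1 of the 4 values shown sits.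

The compounds shown leave open exactly at what chain length the numbers turn from falling to rising, as no chain shown is longer than that of compound 2 yet shorter than that of compound 3. Also open, on these data alone, is what a long chain carrying an amine or a carboxylic acid would give in this assay.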